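Shortening a linker and adding chlorine: lipophilicity of compound 4

The source may hold more compounds than are shown below. What is called first, only, known or untested is meant among the compounds shown, and "the series" means these compounds.

Of the compounds shown here, three sharing one core have been measured in a physicochemical assay for lipophilicity; a higher number here means a more lipophilic compound, a lower number a more polar compound. Compound 1, `Cc1csc2cc([C@H](C)Nc3ncnc(N)c3C#N)c(-c3cccc(CC4CCN(C(C)C)CC4)c3)c(=O)n12`, gives 1.1. Compound 2, `Cc1csc2cc([C@H](C)Nc3ncnc(N)c3C#N)c(-c3cccc(CN(C)CCCCN(C)Cc4ccccc4)c3)c(=O)n12`, gives 2.2. Compound 3, `Cc1csc2cc([C@H](C)Nc3ncnc(N)c3C#N)c(Cc3cccc(CN4CCC4)c3)c(=O)n12`, gives 0.5. In this assay compound 2 stands highest of the three, a step beyond the scatter above compound 1 and further still above compound 3.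

Compound 4, `Cc1csc2cc([C@H](C)Nc3ncnc(N)c3C#N)c(-c3cccc(CN(C)CCCN(C)Cc4ccc(Cl)cc4)c3)c(=O)n12`, is not yet measured. It differs from compound 2 in one place: (4-chlorobenzyl)(methyl)amino in place of (benzyl(methyl)amino)methyl on a saturated chain carbon, three bonds along the chain from an amine nitrogen. The aromatic ring at the end of the chain now carries a chlorine, and the chain between the two amine nitrogens is one carbon shorter.

Within the data shown here, no measured pair shows this exact change, so the expectation rests only on compound 2. Because compound 2 gives 2.2, compound 4 is expected to land close to it, and the step of a number 0.30 log units higher from compound 2 to compound 4 (within the scatter) is estimated to be a small rise, near the edge of the scatter. Compound 4 is therefore estimated at 2.5, within a range from 1.9 to 3.1.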

Compound 4, distribution coefficient: 3.2
Beside the measured number, compound 4's estimate is 0.70 log units below it; the measured number lies above the stated range.
By their numbers in this assay, from the lowest: compound 3; then compound 1; then compound 2; then compound 4.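

At this position, on a saturated chain carbon, three bonds along the chain from an amine nitrogen, (4-chlorobenzyl)(methyl)amino in place of (benzyl(methyl)amino)methyl gives a number 1.00 log units higher from compound 2 to compound 4 (beyond the scatter) in this assay. Among these compounds, the two groups have the same count of heavy atoms, so a change at the end of this chain can move the reading beyond the scatter with no change in that count, which the earlier compounds, with no pair differing in one place, could not show. No measurement shown gives a reason for this step.

The step combines the added chlorine with the shorter chain, and the compounds shown do not divide it between them. A plain benzyl group on the shorter chain, a 4-chlorobenzyl group on the longer chain, or a 4-methoxybenzyl group at this place would each remain to be compared.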